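The compounds below may be only part of what the source reports. "The series", "measured", "known", "first", "only" and "open" are said of these compounds alone.

Series values in a functional assay on MCF7 cells (Homo sapiens) for cytotoxicity, read by MTT assay, with a stated time of 72 h; a higher number here means a weaker inhibitor, a lower number a stronger inhibitor:

- compound 1 `COc1cc2ncnc(Nc3ccc(F)c(Cl)c3)c2cc1NC(=O)/C=C/c1ccccc1[N+](=O)[O-]`: 36500 nM
- compound 2 `COc1ccc(/C=C/C(=O)Nc2cc3c(Nc4ccc(F)c(Cl)c4)ncnc3cc2OC)c(OC)c1`: 36600 nM
- compound 3 `COc1cc(/C=C/C(=O)Nc2cc3c(Nc4ccc(F)c(Cl)c4)ncnc3cc2OC)cc(OC)c1`: 38500 nM

Compound 3 stands level with the other two compounds, since all three values lie within the scatter of one another. The next compound, compound 4 `COc1cc2ncnc(Nc3ccc(F)c(Cl)c3)c2cc1NC(=O)/C=C/c1cc(OC)c(OC)c(OC)c1`, follows from compound 3 by methoxy in place of hydrogen on an aromatic carbon. In words, this is methoxy in place of hydrogen on an aromatic carbon, taking 3,5-dimethoxyphenyl to 3,4,5-trimethoxyphenyl.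

Among the measured compounds shown here, no measured step adds this methoxy directly. The nearest evidence comes from the three exchanges of the aryl group: a 1.0-fold higher number from compound 1 to compound 2 (0.00 log units; within the scatter), a 1.1-fold higher number from compound 1 to compound 3 (0.02 log units; within the scatter) and a 1.1-fold higher number from compound 2 to compound 3 (0.02 log units; within the scatter). All three are within the scatter, so this assay has so far not separated these aryl groups. Three compounds are a small base, and a new substituent could still act differently.

No step beyond the scatter is therefore expected, and the estimated step is a 1.1-fold lower number from compound 3 to compound 4 (0.04 log units; within the scatter). For compound 4 the expected value is 35000 nM, with an estimated range of 17000 nM to 60000 nM.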

Compound 4, half-maximal inhibitory concentration: "not active" (no number reported)
Compound 4 has no reported number here, and the estimate cannot be compared.
By their numbers in this assay, from the lowest: compounds 1, 2 and 3 (each within the scatter of the next).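

Among the compounds shown here, compound 4 is reported as "not active" without a number in this assay, and no step from compound 3 to compound 4 can be read. No available evidence bears on this result. The compounds shown leave open how 3,4,5-trimethoxyphenyl compares numerically with 3,5-dimethoxyphenyl in this assay.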